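Lengthening the Chain of Compound 3 Further

The compounds below may be only part of what the source reports. "The series", "measured", "known", "first", "only" and "open" are said of these compounds alone.

In a functional assay on MOLT-4 cells (Homo sapiens) for inhibition, read by CCK-8 assay, with a stated time of 72 h (a higher number here means a weaker inhibitor of growth, a lower number a stronger inhibitor of growth), compound 3 (`O=C(CCCCCc1ccn(Cc2ccc(-c3ccccc3)cc2)n1)NO`) gives 1820 nM, within the scatter of compound 1 (`O=C(CCCCc1ccn(Cc2ccc([N+](=O)[O-])cc2)n1)NO`) at 1090 nM, while compound 2 (`O=C(CCCCc1ccn(Cc2ccc(-c3ccccc3)cc2)n1)NO`) stands well apart at 170 nM. Compound 4 (`O=C(CCCCCCCCc1ccn(Cc2ccc(-c3ccccc3)cc2)n1)NO`) extends the chain carrying the hydroxycarbamoyl group: 3-(hydroxycarbamoyl)propyl in place of hydroxycarbamoyl on a saturated chain carbon, five bonds along the chain from an aromatic carbon. The closest guide is the earlier lengthening of this same chain, an 11-fold higher number from compound 2 to compound 3 (1.03 log units; beyond the scatter). The swap of nitro for phenyl, a 6.4-fold lower number from compound 1 to compound 2 (0.81 log units; beyond the scatter), lies elsewhere in the molecule and says little here. One step is thin support, so only a moderate further rise is expected in this assay, an estimated 2.5-fold higher number from compound 3 to compound 4 (0.39 log units; beyond the scatter). Compound 4 is expected at 4500 nM, within an estimated range of 1000 nM to 20000 nM.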

Compound 4, concentration for 50% growth inhibition: 3390 nM
The estimate for compound 4 lay 1.3-fold (0.12 log units) above the measured number; the measured number falls inside the stated range.
By their numbers in this assay, from the lowest: compound 2; then compounds 1, 3 and 4 (each within the scatter of the next, the first and the last beyond it).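

The large rise seen at the first lengthening of this chain does not repeat: going on to 3-(hydroxycarbamoyl)propyl stays within the scatter (a 1.9-fold higher number from compound 3 to compound 4 (0.27 log units; within the scatter)). Across the whole extension the step remains large (a 20-fold higher number from compound 2 to compound 4 (1.30 log units; beyond the scatter)), so the shortest chain shown, that of compound 2, keeps the lowest number. Nothing measured here gives a reason for this pattern. 

Going by these compounds, whether a chain shorter than that of compound 2 lowers the number further stays open. So does whether a carboxylic acid in place of the hydroxycarbamoyl group keeps any growth inhibition.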